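Anilino-lactone analogues of the core: compound 4 expectation

A few compounds are considered here, and "the series" means these few. Any claim that something is new, unique, unknown or untested is made for them only; others in the source may bear on it.

Measured so far:
- compound 1 `C=C1[C@@H](C/C=C2/C(=O)OC[C@H]2OC(C)=O)[C@]2(C)CC[C@@H](OC(C)=O)[C@@](C)(CO[Si](C)(C)C(C)(C)C)[C@H]2C[C@@H]1O` — 6960 nM
- compound 2 `C=C1[C@@H](OC(C)=O)C[C@@H]2[C@](C)(CO[Si](C)(C)C(C)(C)C)[C@H](OC(C)=O)CC[C@@]2(C)[C@@H]1C[C@@H](Nc1ccccc1F)C1=CCOC1=O` — 2930 nM
- compound 3 `C=C1[C@@H](OC(C)=O)C[C@@H]2[C@](C)(COC=O)[C@H](OC(C)=O)CC[C@@]2(C)[C@@H]1C[C@@H](Nc1ccc(Br)cc1)C1=CCOC1=O` — 11400 nM

In a functional assay on MCF7 cells (Homo sapiens) for cytotoxicity, read by sulforhodamine B assay (on this read-out higher numbers stand for weaker inhibition and lower numbers for stronger inhibition), compound 2 gives 2930 nM and stands lowest of the three numbers. Compound 1 gives 6960 nM in this assay, the nearest to compound 2, and the gap lies beyond the scatter. Compound 3 gives 11400 nM in this assay, the furthest from compound 2, also beyond the scatter. None of these three differ in only one place, so no single-change step can be read from them; the numbers show only that the three anilino-bearing and side-chain variants span a moderate range.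

Compound 4 `C=C1[C@@H](OC(C)=O)C[C@@H]2[C@](C)(CO[Si](C)(C)C(C)(C)C)[C@H](OC(C)=O)CC[C@@]2(C)[C@@H]1C[C@@H](Nc1ccc(C(=O)O)cc1)C1=CCOC1=O` is yet to be measured in this assay. It differs from compound 2 as follows: 4-carboxyphenyl in place of 2-fluorophenyl on an amine nitrogen.

Going by the values given here, no measured pair isolates this kind of change, so the expectation rests on the range seen across compounds 1 to 3 alone. A modest rise in the number is expected, from compound 2 to compound 4 of a 2.2-fold higher number from compound 2 to compound 4 (0.35 log units; beyond the scatter), and the step is expected to reach somewhat beyond the scatter. Compound 4 is estimated at 6500 nM, with a range from 2200 nM to 20000 nM.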

Compound 4, half-maximal inhibitory concentration: 3990 nM
For compound 4 the middle estimate is 1.6-fold (0.21 log units) above the measured one; measured number inside the range.
By their numbers in this assay, from the lowest: compounds 2, 4, 1 and 3 (each within the scatter of the next, the first and the last beyond it).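

In this assay, going by these compounds alone, 4-carboxyphenyl in place of 2-fluorophenyl on the amine nitrogen gives a 1.4-fold higher number from compound 2 to compound 4 (0.13 log units; within the scatter), the only single-place step available in this set. At this position, the read-out therefore does not separate the two aryl groups, even though the swap adds a hydrogen-bond donor and a hydrogen-bond acceptor to the group. No measurement bearing on the reason for this result is available.

Steps linking compound 1 or compound 3 to the other compounds cannot be read, so the effects of the remaining structural differences stay unresolved. Also open, on these data alone, is whether an unsubstituted phenyl, or a methyl ester or primary amide in place of the carboxylic acid, would likewise remain within the scatter of compound 2.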